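The source may report more compounds than this note shows. Statements on the series, on what has been measured and on what is new or still open speak of the compounds shown alone.

Measured compounds:
- compound 1, `COC(=O)c1c(F)cccc1-c1ccc(CCc2ncc(CC(C)(C)C)n2Cc2ccc(C(=O)O)cc2)cc1`: 5 nM
- compound 2, `CC(C)(C)Cc1cnc(CCc2ccc(-c3cccc(F)c3C(=O)O)cc2)n1CCC(=O)O`: 61 nM

Both were tested in an assay on cells for agonist activity at Bombesin receptor subtype-3 (Mus musculus), read by HTRF and inositol phosphate accumulation, with a stated time of 1 h; a higher number here means that more compound is needed for the effect, a lower number that less compound is needed. Compound 2 stands at the higher of the two numbers, and its neighbour compound 1 lies a long way off: the gap between them is well beyond the scatter of repeated runs, so compound 2 needs clearly more material for the same effect than compound 1 does.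

Compound 3, `CC(C)(C)Cc1cnc(CCc2ccc(-c3cccc(F)c3C(=O)O)cc2)n1Cc1ccc(C(=O)O)cc1`, has not yet been measured. It is built from compound 2 by one change: 4-carboxyphenyl in place of carboxymethyl on a saturated chain carbon bound to an aromatic nitrogen. In plain words, the short acid-bearing chain on the core nitrogen is replaced by a benzyl group that carries the acid on the ring. Compound 1 carries this same benzyl acid, and compound 1 gives 5 nM in this assay, while compound 2 with the shorter chain gives 61 nM. Within the data shown here, since no step between measured compounds is available, the change can only be judged by what these two values show. The expectation is a drop toward the number of compound 1, a step of about a 6.1-fold lower number from compound 2 to compound 3 (0.79 log units; beyond the scatter), well beyond the scatter. Compound 3 is estimated at 10 nM, with a range from 3 nM to 40 nM.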

Compound 3, half-maximal effective concentration: 13 nM
Estimate against measurement, compound 3: 1.3-fold (0.11 log units) below; the range from low to high includes it.
By their numbers in this assay, from the lowest: compound 1; then compound 3; then compound 2.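

In this assay, among these compounds, putting 4-carboxyphenyl in place of carboxymethyl on a saturated chain carbon bound to an aromatic nitrogen gives a 4.7-fold lower number from compound 2 to compound 3 (0.67 log units; beyond the scatter) and so gives a first direct reading of this change, with all else held the same: the larger group with its aromatic ring is accepted at this position, and the number improves modestly. The second step, with hydrogen in place of methyl on an oxygen next to a carbonyl group, is a 2.6-fold higher number from compound 1 to compound 3 (0.41 log units; beyond the scatter) and is also modest, so this second place matters too, and here the hydrogen form carries the higher number. Nothing available explains the direction or size of either step.

The compounds shown leave open whether the gain needs the carboxylic acid on the ring at all, which a plain benzyl group would test, or whether an amide in that spot would serve as well. They also leave open whether a chain longer than 2-carboxyethyl, without any ring, would bring a similar drop in the number.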